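The source may report more compounds than this note shows. Statements on the series, on what has been measured and on what is new or still open speak of the compounds shown alone.

In an ADME assay on NIH3T3 cells (Mus musculus) for cytotoxicity, read by crystal violet staining (on this read-out higher numbers stand for weaker inhibition and lower numbers for stronger inhibition), compound 1, `COc1ccc(CNC(=O)C(CCCCCNC(=O)OC(C)(C)C)NC(=O)CNC(=O)OCc2ccccc2)cc1`, gives > 100000 nM, which is a limit of the assay rather than a number, as the limit of > 100000 nM in this assay, at which 1 of the 2 values shown sits, shows. Compound 2, `COc1ccc(CNC(=O)C(NC(=O)CNC(=O)OCc2ccccc2)C2CCCCC2)cc1`, gives 50000 nM in this assay. Going by the values given here, compound 2 thus stands as the only plain number among the two values, the other being a limit. Compound 3, `COc1ccc(CNC(=O)C(CC(C)C)NC(=O)CNC(=O)OCc2ccccc2)cc1`, differs from compound 2 by isobutyl in place of cyclohexyl on a saturated chain carbon bound to an amide-type nitrogen and a carbonyl carbon. Among the compounds with values here, no measured pair covers this change, so the step from compound 2 to compound 3 is expected to stay within the usual scatter, about a 1.2-fold higher number from compound 2 to compound 3 (0.08 log units; within the scatter). Compound 3 is estimated at 60000 nM, between 25000 nM and 150000 nM.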

Compound 3, half-maximal inhibitory concentration: > 100000 nM
Compound 3 ended at the assay's limit; the forecaster's own chance of this, stated with the estimate: 35%; middle value at least 1.6-fold (0.22 log units) away from the limit.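

In this assay, isobutyl in place of cyclohexyl on a saturated chain carbon bound to an amide-type nitrogen and a carbonyl carbon gives an at least 2.0-fold higher number from compound 2 to compound 3 (0.30 log units; that floor lies within the scatter), so going from a ring to an open chain here cannot yet be told apart from scatter. The step between compound 1 and compound 3 cannot be read. Compound 2 remains the only compound with a plain number: the limit of > 100000 nM in this assay, at which 2 of the 3 values shown sit.

Going by these compounds, how far past its limit compound 3 lies stays open. So does whether an amine or a carboxylic acid on this carbon would give a plain number.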